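Swapping Bromo for Tert-Butyl on the Phenyl Ring

The source may report more compounds than this note shows. Statements on the series, on what has been measured and on what is new or still open speak of the compounds shown alone.

Compound 3 `C/C(=C\CC/C(C)=C/CC[C@@H]1[C@@]2(C)CCC(=O)C(C)(C)[C@H]2CC[C@@]1(C)O)CC/C=C(\C)C(=O)OCc1cn(-c2ccc(Br)cc2)nn1` stands at the weak end of what has been measured. In a functional assay on DU-145 cells (Homo sapiens) for antiproliferative activity, read by MTT assay, with a stated time of 48 h (on this read-out higher numbers stand for weaker inhibition and lower numbers for stronger inhibition), compound 3 gives only a limit of the assay, > 150000 nM, and not a number. Compound 2 `C/C(=C\CC/C(C)=C/CC[C@@H]1[C@@]2(C)CCC(=O)C(C)(C)[C@H]2CC[C@@]1(C)O)CC/C=C(\C)C(=O)OCc1cn(-c2ccccc2C)nn1` likewise gives only a limit in this assay, > 150000 nM. Compound 1 `C/C(=C\CC/C(C)=C/CC[C@@H]1[C@@]2(C)CCC(=O)C(C)(C)[C@H]2CC[C@@]1(C)O)CC/C=C(\C)C(=O)OCc1cn(-c2cccc(O)c2)nn1`, which carries 3-hydroxyphenyl, gives 28400 nM in this assay. The two steps away from compound 1 are an at least 5.2-fold higher number from compound 1 to compound 2 (0.72 log units; beyond the scatter) and an at least 5.2-fold higher number from compound 1 to compound 3 (0.72 log units; beyond the scatter), both pointing toward weaker inhibition; the step that the two limits leave unreadable from compound 2 to compound 3 cannot be sized, as the limit of > 150000 nM in this assay, at which 2 of the 3 values shown sit, shows. Compound 4 `C/C(=C\CC/C(C)=C/CC[C@@H]1[C@@]2(C)CCC(=O)C(C)(C)[C@H]2CC[C@@]1(C)O)CC/C=C(\C)C(=O)OCc1cn(-c2ccc(C(C)(C)C)cc2)nn1` differs from compound 3 in one place: tert-butyl in place of bromo on an aromatic carbon. Within the data shown here, no measured step touches this position, and neither 2-methylphenyl nor 4-bromophenyl reached a number, so there is nothing to suggest that a tert-butyl would do so. Compound 4 is therefore expected to stay at or beyond the limit, estimated at 200000 nM (range 100000 nM to 400000 nM). The expected step is a step that the limit leaves unreadable from compound 3 to compound 4.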

Compound 4, half-maximal inhibitory concentration: > 150000 nM
Compound 4: a limit, no number (the forecaster's own chance of this, stated with the estimate: 75%); the middle value is on the limit's open side.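

In this assay, the position that held bromo now has a change to read, and tert-butyl in its place also ends at a limit and not a number. Against compound 1, which carries 3-hydroxyphenyl, the result is an at least 5.2-fold higher number from compound 1 to compound 4 (0.72 log units; beyond the scatter), so a third phenyl ring with a different group, here 4-(tert-butyl)phenyl, falls on the weak side of compound 1. The steps from compound 2 and compound 3 to compound 4 cannot be read, and the effect of this swap stays without a size: the limit of > 150000 nM in this assay, at which 3 of the 4 values shown sit.

Going by these compounds, whether an amine or a carboxylic acid in place of bromo would bring back a measurable number stays open. Also open, on these data alone, is whether compound 1 owes its number to the hydroxy group itself or to where that group sits on the ring.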